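Closing the amine into a pyrrolidine ring

A few compounds are considered here, and "the series" means these few. Any claim that something is new, unique, unknown or untested is made for them only; others in the source may bear on it.

In a functional assay on PC-3 cells (Homo sapiens) for cytotoxicity, read by MTT assay, with a stated time of 48 h (a lower number here means a stronger inhibitor, a higher number a weaker inhibitor), compound 1 `O=C(CNC1CC1)N1N=C(c2cc3ccccc3oc2=O)CC1c1ccccc1` gives 28500 nM, and compound 2 `O=C(CNC1CCCCC1)N1N=C(c2cc3ccccc3oc2=O)CC1c1ccccc1` gives 48500 nM, the higher of the two numbers, although the gap stays within the scatter. Compound 3 `O=C(CN1CCCC1)N1N=C(c2cc3ccccc3oc2=O)CC1c1ccccc1` carries pyrrolidin-1-yl in place of cyclohexylamino on a saturated chain carbon bound to a carbonyl carbon. Going by the values given here, no measured step exchanges a secondary amine for a ring nitrogen, and the only step known, a 1.7-fold higher number from compound 1 to compound 2 (0.23 log units; within the scatter), was small. Compound 3 is therefore expected to shift only a 1.4-fold lower number from compound 2 to compound 3 (0.14 log units; within the scatter), a change within the scatter. The estimate for compound 3 is 35000 nM, with a range from 12000 nM to 100000 nM.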

Compound 3, half-maximal inhibitory concentration: 50200 nM
Estimate against measurement, compound 3: 1.4-fold (0.16 log units) below; the measured number falls inside the stated range.
By their numbers in this assay, from the lowest: compounds 1, 2 and 3 (each within the scatter of the next).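

Putting pyrrolidin-1-yl in place of cyclohexylamino takes away the hydrogen-bond donor of the leaving group, yet this assay shows only a 1.0-fold higher number from compound 2 to compound 3 (0.01 log units; within the scatter). Against cyclopropylamino the picture is the same, with a 1.8-fold higher number from compound 1 to compound 3 (0.25 log units; within the scatter). So on this saturated chain carbon bound to a carbonyl carbon, a nitrogen held inside the ring reads no differently from one carrying a ring as a substituent, and no measurement offers an explanation. From the compounds shown here alone, whether a carboxylic acid or a longer chain ending in an amine at this place would give a step beyond the scatter stays open.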